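A few compounds are considered here, and "the series" means these few. Any claim that something is new, unique, unknown or untested is made for them only; others in the source may bear on it.

Measured compounds:
Compound 1, `COc1cc(C(=O)c2sc3ccccc3c2-c2ccc(Cl)cc2)cc(OC)c1OC`; in a functional assay on Jurkat cells (Homo sapiens) for antiproliferative activity, read by MTT assay, with a stated time of 72 h (on this read-out lower numbers stand for stronger inhibition and higher numbers for weaker inhibition), compound 1 gives 3700 nM.
Compound 2, `COc1cc(C(=O)c2sc3ccccc3c2-c2ccc(C)cc2)cc(OC)c1OC`; in this assay compound 2 gives 3300 nM.
Compound 3, `COc1cc(C(=O)c2sc3ccccc3c2Nc2ccc(Cl)cc2)cc(OC)c1OC`; in this assay compound 3 gives 1900 nM.

Compound 4, `COc1cc(C(=O)c2sc3ccccc3c2Nc2ccc(C)cc2)cc(OC)c1OC`, is not yet measured. The difference between compound 3 and compound 4 is methyl in place of chloro on an aromatic carbon. The same change has been made once before in this series, from compound 1 to compound 2, where the difference is methyl in place of chloro on an aromatic carbon and the step in this assay is a 1.1-fold lower number from compound 1 to compound 2 (0.05 log units; within the scatter). The two place lines are the same word for word, so it is the same change on a different core. The two cores differ as described by (4-chlorophenyl)amino in place of 4-chlorophenyl on an aromatic carbon; the step for that core change in this assay is a 1.9-fold lower number from compound 1 to compound 3 (0.29 log units; within the scatter), and a 1.7-fold lower number from compound 2 to compound 3 (0.24 log units; within the scatter) points the same way. All three measured values lie within the usual scatter of one another, so no ordering among them can be claimed.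

Within the data shown here, for compound 4 the step from compound 3 is expected to be small, about a 1.1-fold lower number from compound 3 to compound 4 (0.05 log units; within the scatter), resting on the single precedent a 1.1-fold lower number from compound 1 to compound 2 (0.05 log units; within the scatter). Compound 4 is therefore estimated at 1700 nM in this assay, expected between 800 nM and 3600 nM.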

Compound 4, half-maximal inhibitory concentration: 1700 nM
Compound 4: middle estimate and measured number agree at the digits printed, within the range that was stated.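

Methyl in place of chloro on an aromatic carbon carries over from the core of compound 1 to the core of compound 3 with no detectable difference in this assay: the same change on two cores in this assay, a 1.1-fold lower number (0.05 log units; within the scatter) from compound 1 to compound 2 and a 1.1-fold lower number (0.05 log units; within the scatter) from compound 3 to compound 4, 1.0-fold (0.00 log units) apart, within the scatter of two such steps. Among these compounds, the new step, a 1.1-fold lower number from compound 3 to compound 4 (0.05 log units; within the scatter), shows only that this swap does little on either of these two cores; with two small steps as the whole basis, it does not show that the change would stay small on any other core. On the core change, (4-methylphenyl)amino in place of 4-methylphenyl gives a 1.9-fold lower number from compound 2 to compound 4 (0.29 log units; within the scatter), while (4-methylphenyl)amino in place of 4-chlorophenyl gives a 2.2-fold lower number from compound 1 to compound 4 (0.34 log units; beyond the scatter), a modest step that alone passes the scatter and also contains the swap of chloro for methyl.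

From the compounds shown here alone, it remains open whether a different group at this position, such as methoxy, a dimethylamino group or a carboxylic acid, would move the number beyond the scatter on either core. Going by these compounds, whether the small step for methyl and chloro also holds in other cell lines is likewise open.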